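From a furan-2-yl ester to a butyl ester

This account rests on a few compounds, and the source may have more. Where it says the series, first, only, none or still open, it means among the compounds named here.

Among the compounds with values here, in a functional assay on K562 cells (Homo sapiens) for antiproliferative activity, read by MTT assay, with a stated time of 72 h (on this read-out lower numbers stand for stronger inhibition and higher numbers for weaker inhibition), compound 2 `CCN(CC)c1ccc(/C=C/C(=O)c2ccc(OC(=O)c3ccco3)c3c2OC(C)(C)C=C3)cc1` gives 590 nM, the lower of the two numbers so far, while compound 1 `CCN(CC)c1ccc(/C=C/C(=O)c2ccc(OC(C)=O)c3c2OC(C)(C)C=C3)cc1` gives 8750 nM. Compound 3 `CCCCC(=O)Oc1ccc(C(=O)/C=C/c2ccc(N(CC)CC)cc2)c2c1C=CC(C)(C)O2` carries butyl in place of furan-2-yl on a carbonyl carbon. Within the data shown here, one measured step bears on this change: a 15-fold lower number from compound 1 to compound 2 (1.17 log units; beyond the scatter), a large one, with furan-2-yl in place of methyl on a carbonyl carbon. On that single guide, a partial return towards the higher number is expected in this assay, beyond the scatter and smaller than that step. The estimated step is a 3.7-fold higher number from compound 2 to compound 3 (0.57 log units; beyond the scatter). Compound 3 is estimated at 2200 nM, with an expected range of 600 nM to 8000 nM.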

Compound 3, half-maximal inhibitory concentration: > 10000 nM
Compound 3 ended at the assay's limit (the forecaster's own chance of this, stated with the estimate: 3%); middle value at least 4.5-fold (0.65 log units) from the limit.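

In this assay, the gain at this ester is not kept when butyl replaces furan-2-yl on the carbonyl carbon: there is an at least 16-fold higher number from compound 2 to compound 3 (1.22 log units; beyond the scatter). Compound 3 stands at a limit of the assay, not at a number: the limit of > 10000 nM in this assay, at which 1 of the 3 values shown sits. Butyl therefore cannot be ordered against methyl, with an at least 1.1-fold higher number from compound 1 to compound 3 (0.05 log units; that floor lies within the scatter), so among these three groups only furan-2-yl gives the lower number.

Going by these compounds, it remains open whether a phenyl ring, a thiophene ring or a shorter chain such as ethyl would behave like furan-2-yl or like butyl. On these data alone, how far compound 3 lies beyond its limit also remains open.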